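Working notes: varying the group on the triple-bonded carbon

The source may hold more compounds than are shown below. What is called first, only, known or untested is meant among the compounds shown, and "the series" means these compounds.

Measured so far in a functional assay on BaF3 cells (Mus musculus) for antiproliferative activity; a lower number here means that less compound is needed, a higher number that more compound is needed for the effect
- compound 1 `CCN1CCN(Cc2ccc(NC(=O)c3ccc(C)c(C#Cc4ccc(NC(C)=O)nc4)c3)cc2C(F)(F)F)CC1` gives 2050 nM
- compound 2 `CCN1CCN(Cc2ccc(NC(=O)c3ccc(C)c(C#Cc4ccc(NC(=O)C5CC5)nc4)c3)cc2C(F)(F)F)CC1` gives 1800 nM
- compound 3 `CCN1CCN(Cc2ccc(NC(=O)c3ccc(C)c(C#Cc4cncnc4)c3)cc2C(F)(F)F)CC1` gives 2190 nM

Compound 2 stands level with the other two compounds, as both of its steps lie within the scatter (a 1.1-fold lower number from compound 1 to compound 2 (0.06 log units; within the scatter); a 1.2-fold higher number from compound 2 to compound 3 (0.09 log units; within the scatter)). The next structure is compound 4 `CCN1CCN(Cc2ccc(NC(=O)c3ccc(C)c(C#Cc4cnc5[nH]ccc5c4)c3)cc2C(F)(F)F)CC1`, which carries a group of 9 heavy atoms (7 carbon, 2 nitrogen; one five-membered aromatic ring with 1 hetero atom, one six-membered aromatic ring with 1 hetero atom) in place of a group of 12 heavy atoms (9 carbon, 2 nitrogen, 1 oxygen; one three-membered non-aromatic ring of carbon only, one six-membered aromatic ring with 1 hetero atom), on a triple-bonded carbon and keeps the rest of the core of compound 2.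

The two steps at this same place are the closest guide. Pyrimidin-5-yl in place of 6-acetamidopyridin-3-yl gave a 1.1-fold higher number from compound 1 to compound 3 (0.03 log units; within the scatter) and the same group in place of 6-((cyclopropylcarbonyl)amino)pyridin-3-yl is the step from compound 2 already given above. Neither left the scatter, and the change on the carbonyl carbon did not either. For the measured compounds named here, none of the measured compounds carries a five-membered aromatic ring, so the data do not cover the entering group, and the range has to stay wide.

In this assay the expected step is a 1.2-fold lower number from compound 2 to compound 4 (0.08 log units; within the scatter) and so no step beyond the scatter is expected, in either direction. For compound 4 the estimated value is 1500 nM with an expected range from 350 nM to 4000 nM in this estimate.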

Compound 4, half-maximal effective concentration: 1000 nM
Compound 4: the middle estimate sits 1.5-fold (0.18 log units) above what was measured; the range from low to high includes it.
By their numbers in this assay, from the lowest: compounds 4, 2, 1 and 3 (each within the scatter of the next, the first and the last beyond it).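

For the compounds shown here, at this place on the triple-bonded carbon, the group with one five-membered and one six-membered aromatic ring gives the only steps in this assay that leave the scatter, both modest (a 2.2-fold lower number from compound 3 to compound 4 (0.34 log units; beyond the scatter)) and (a 2.1-fold lower number from compound 1 to compound 4 (0.31 log units; beyond the scatter)). Against 6-((cyclopropylcarbonyl)amino)pyridin-3-yl the same change stays within the scatter (a 1.8-fold lower number from compound 2 to compound 4 (0.26 log units; within the scatter)), so compound 4 stands level with compound 2 and separates only from compound 1 and compound 3, which shows that the position tolerates a group with no carbonyl and a fused pair of aromatic rings without any loss, and that the number can move here, if only slightly, while compound 2 remains the exception to any clear gain. No measurement shown bears on the cause of these steps.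

The compounds shown do not separate the contribution of the five-membered aromatic ring from that of the missing amide, which a plain pyridin-3-yl on the triple-bonded carbon would begin to address. Also open, from the compounds shown here alone, is whether an amine or a carboxylic acid on the six-membered aromatic ring of the entering group would move the number any further than the modest steps seen so far.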